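Thiadiazole for oxadiazole on two chromone cores

A few compounds are considered here, and "the series" means these few. Any claim that something is new, unique, unknown or untested is made for them only; others in the source may bear on it.

Measured so far in a functional assay on MCF7 cells (Homo sapiens) for cytotoxicity, read by MTT assay, with a stated time of 72 h; a lower number here means a stronger inhibitor, a higher number a weaker inhibitor:
compound 1, `Cc1nnc(SCc2cc(=O)c3ccccc3o2)o1`: > 25000 nM
compound 2, `Nc1nnc(SCc2cc(=O)c3ccccc3o2)s1`: > 25000 nM
compound 3, `Cc1nnc(SCc2coc3ccccc3c2=O)o1`: 4600 nM

The value given for compound 1 is a limit of the assay, not a number. The value given for compound 2 is likewise a limit. Compound 3 is the only one of the three with a measured number, and in this assay compound 3 gives 4600 nM. Compound 1 and compound 3 are built from the same atoms joined differently; the difference between the two cores is not broken down here.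

From compound 1 to compound 2 the change is 5-amino-1,3,4-thiadiazol-2-yl in place of 5-methyl-1,3,4-oxadiazol-2-yl on a sulfur. The step that the two limits leave unreadable from compound 1 to compound 2 cannot be read, because of the limit of > 25000 nM in this assay, at which 2 of the 3 values shown sit. The same change is now to be made on the core of compound 3, giving compound 4, `Nc1nnc(SCc2coc3ccccc3c2=O)s1`, which has yet to be measured: 5-amino-1,3,4-thiadiazol-2-yl in place of 5-methyl-1,3,4-oxadiazol-2-yl on a sulfur.

For the measured compounds named here, with the only earlier instance of this change unreadable, the expectation for compound 4 rests on compound 3 alone, because compound 3 gives 4600 nM in this assay. Compound 4 is therefore expected to land near 6000 nM, with a likely range of 2000 nM to 20000 nM. That estimate corresponds to an expected step of a 1.3-fold higher number from compound 3 to compound 4 (0.12 log units; within the scatter) in this assay, small enough to sit within ordinary scatter.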

Compound 4, half-maximal inhibitory concentration: > 25000 nM
Compound 4 gave a limit, no number; the forecaster's own chance of this, stated with the estimate: 20%; middle value at least 4.1-fold (0.61 log units) away from the limit.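

In this assay, for the compounds shown here, replacing 5-methyl-1,3,4-oxadiazol-2-yl with 5-amino-1,3,4-thiadiazol-2-yl on a sulfur gives an at least 5.4-fold higher number from compound 3 to compound 4 (0.73 log units; beyond the scatter), so on the core of compound 3 the change clearly weakens the compound, and this is the one instance of the change that can be read. The value of compound 4, > 25000 nM, is a limit of the assay and not a number. The same change on the core of compound 1 cannot be read, so the series shows neither that the change carries from one core to the other nor that it behaves differently on each, for a single reason: the limit of > 25000 nM in this assay, at which 3 of the 4 values shown sit.

The compounds shown also leave open which part of the exchange matters on the core of compound 3, the sulfur in place of the oxygen in the ring or the amine in place of the methyl, as the two always change together here. A 5-methyl-1,3,4-thiadiazol-2-yl or a 5-amino-1,3,4-oxadiazol-2-yl on that sulfur would separate the two, but neither group is among the compounds shown.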